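The source may report more compounds than this note shows. Statements on the series, on what has been measured and on what is new or still open speak of the compounds shown alone.

Working notes on the series: in a physicochemical assay for acid dissociation, compound 1 `NS(=O)(=O)c1ccc(SCCCO)c(Cl)c1` reads 9.45 and compound 2 `NS(=O)(=O)c1ccc(S(=O)(=O)CCCO)c(C(=O)O)c1` reads 9.28 while compound 3 `CC(=O)OCCCc1ccc(S(N)(=O)=O)cc1` reads 10.2 as the highest of the three numbers. Compound 3 stands beyond the scatter from both of the others, with compound 1 the nearer and compound 2 the further. Compound 4 `CC(=O)OCCCCCc1ccc(S(N)(=O)=O)cc1` departs from compound 3 by 2-acetoxyethyl in place of acetoxy on a saturated chain carbon, three bonds along the chain from an aromatic carbon with 2-acetoxyethyl in place of acetoxy on a saturated chain carbon, three bonds along the chain from an aromatic carbon. For the measured compounds named here, no measured pair differs in one place only, so the data offer no direct step, and the step expected in this assay is none beyond the scatter. The estimate amounts to no change at the digits printed from compound 3 to compound 4 (within the scatter) in expectation. Compound 4 is estimated at 10.2 with an expected range from 9.9 to 10.5 for the coming measurement.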

Compound 4, acid dissociation constant: 10.3
Beside the measured number, compound 4's estimate is 0.10 log units below it; the range from low to high includes it.
By their numbers in this assay, from the lowest: compounds 2 and 1 (each within the scatter of the next); then compounds 3 and 4 (each within the scatter of the next).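

In this assay the series now has its first step at a single place, with a number 0.10 log units higher from compound 3 to compound 4 (within the scatter) for 2-acetoxyethyl in place of acetoxy on a saturated chain carbon, three bonds along the chain from an aromatic carbon. This read-out does not separate the two groups at this position. Nothing measured here bears on a cause for this result.

From the compounds shown here alone, whether a longer chain would also stay within the scatter remains open. So does the reading with an amine or a carboxylic acid in place of the 2-acetoxyethyl group at this position.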